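Cytotoxicity notes: carbamoyl in place of trifluoromethyl

The source may report more compounds than this note shows. Statements on the series, on what has been measured and on what is new or still open speak of the compounds shown alone.

Compound 1 `O=c1n(Cc2cc3cc(Cl)ccc3n2CCCC(F)(F)F)c2cnccc2n1C1CC1` gives > 50000 nM, which is a limit of the assay. Compound 2 `CS(=O)(=O)CCCn1c(Cn2c(=O)n(C3CNC3)c3ccncc32)cc2cc(Cl)ccc21` gives > 50000 nM, also a limit. Compound 3 `COc1ccc(-n2c(=O)n(Cc3cc4cc(Cl)ccc4n3CCCC#N)c3cnccc32)cc1` gives > 50000 nM, again a limit.

In an ADME assay on HeLa cells (Homo sapiens) for cytotoxicity, read by ATP content, with a stated time of 3 days (a lower number here means that less compound is tolerated, a higher number that more compound is tolerated), compound 1 therefore stands at the top of what was reported, and nothing separates it from the other two, since (the limit of > 50000 nM in this assay, at which 3 of the 3 values shown sit). Among the measured compounds shown here, no number below the limit exists for any of the three, so no measured step between them can be sized.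

Compound 4 `NC(=O)CCCn1c(Cn2c(=O)n(C3CC3)c3ccncc32)cc2cc(Cl)ccc21` is not yet measured. It differs from compound 1 by carbamoyl in place of trifluoromethyl on a saturated chain carbon, three bonds along the chain from an aromatic nitrogen, while the core and the remaining substituents of compound 1 are kept.

For the measured compounds named here, with all three measured values sitting at the limit, no step of any size has been seen. The expectation for compound 4 is that it also sits at or near the limit of this assay, so the step that the limit leaves unreadable from compound 1 to compound 4 is expected to be none beyond the scatter. Compound 4 is expected at 80000 nM, within the range 30000 nM to 200000 nM.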

Compound 4, half-maximal cytotoxic concentration: > 50000 nM
Compound 4: no number, only a limit (the forecaster's own chance of this, stated with the estimate: 85%); the middle value does not contradict the limit.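

In this assay compound 4 gives > 50000 nM, which is a limit and not a number. No step from compound 1 to compound 4 can be read, because both compounds sit at that limit: the limit of > 50000 nM in this assay, at which 4 of the 4 values shown sit.

The compounds shown leave open where any of the four would reach a half-maximal cytotoxic concentration, and whether carbamoyl and trifluoromethyl differ there at all.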